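This account rests on a few compounds, and the source may have more. Where it says the series, first, only, none or still open, it means among the compounds named here.

Three compounds built around a shared core were tested in a functional assay on HCT-116 cells (Homo sapiens) for inhibition, read by MTT assay, with a stated time of 72 h, tested at 20 uM; on this read-out lower numbers stand for less inhibition and higher numbers for more inhibition at the one concentration tested (going by the name of the read-out). Compound 2 `c1ccc2c(c1)CCN(c1ccnc(Nc3ccc(Oc4ncnc5ccsc45)cc3)n1)C2` carries a hydrogen on a nitrogen on an aromatic ring, and in this assay compound 2 gives 40.9%. Compound 1 `CN(c1ccc(Oc2ncnc3ccsc23)cc1)c1nccc(N2CCc3ccccc3C2)n1` differs by methyl in place of hydrogen on a nitrogen on an aromatic ring, and in this assay compound 1 gives 58.3%, a change of a number 17.4 percentage points higher from compound 2 to compound 1 (beyond the scatter). Compound 3 `c1ccc2c(c1)CCN(c1ccnc(Nc3ccc(Oc4ncnc5sccc45)cc3)n1)C2` keeps the hydrogen but has a different core, the difference being (a group of 9 heavy atoms (6 carbon, 2 nitrogen, 1 sulfur; one five-membered aromatic ring with 1 hetero atom, one six-membered aromatic ring with 2 hetero atoms) in place of a group of 9 heavy atoms (6 carbon, 2 nitrogen, 1 sulfur; one five-membered aromatic ring with 1 hetero atom, one six-membered aromatic ring with 2 hetero atoms), on an oxygen on an aromatic ring); in this assay compound 3 gives 18.1%, a change of a number 22.8 percentage points lower from compound 2 to compound 3 (beyond the scatter), which leaves compound 3 lowest of the three.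

Compound 4 `CN(c1ccc(Oc2ncnc3sccc23)cc1)c1nccc(N2CCc3ccccc3C2)n1` has not yet been measured. Going by the values given here, it differs from compound 3 by methyl in place of hydrogen on a nitrogen on an aromatic ring, and this is the same change as the one from compound 2 to compound 1, made at the same place. Among the compounds with values here, on the single earlier example, which showed a number 17.4 percentage points higher from compound 2 to compound 1 (beyond the scatter), a step of about a number 16.9 percentage points higher from compound 3 to compound 4 (beyond the scatter) is expected from compound 3 to compound 4 in this assay. Compound 4 is therefore estimated at about 35%, with a likely range from 22% to 48%, although whether the methyl helps equally on the core of compound 3 rests on one comparison only.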

Compound 4, a percentage reported as inhibition, at one concentration (the size of the read-out at that concentration, not a potency): 57.7%
Compound 4: middle estimate off by 22.7 percentage points, on the low side, and the stated range ends below it.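

With methyl in place of hydrogen on the nitrogen, this assay shows a number 39.6 percentage points higher from compound 3 to compound 4 (beyond the scatter), so the direction of the earlier step carried over to the second core, but its size did not: the same change on two cores in this assay, a number 17.4 percentage points higher (beyond the scatter) from compound 2 to compound 1 and a number 39.6 percentage points higher (beyond the scatter) from compound 3 to compound 4, 22.2 percentage points apart, beyond the scatter of two such steps

The two cores stand apart while the nitrogen carries hydrogen, yet with methyl there they show a number 0.6 percentage points lower from compound 1 to compound 4 (within the scatter), so in this series the effects of the core and the methyl cannot simply be added together: the same change on two cores in this assay, a number 22.8 percentage points lower (beyond the scatter) from compound 2 to compound 3 and a number 0.6 percentage points lower (within the scatter) from compound 1 to compound 4, 22.2 percentage points apart, beyond the scatter of two such steps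

Going by these compounds alone, this rests on only two matched pairs, so it shows that the size of the step depends on the core in these compounds, but it does not show why, or what size the step would take on any other core.

The compounds shown leave open whether ethyl or a longer chain on that nitrogen would give a different number from methyl, and whether an acetyl group there would behave in the same way. They also leave open how these compounds compare at other concentrations, as a reading at one concentration is not a potency.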